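From Cyano to Amino on the Aromatic Ring

A few compounds are considered here, and "the series" means these few. Any claim that something is new, unique, unknown or untested is made for them only; others in the source may bear on it.

Compound 1 `Cc1nsc(-c2ccnc(N3CCN(c4cccc(C(F)(F)F)c4)CC3)n2)n1`: > 100 nM, a limit
Compound 2 `Cc1nsc(-c2ccc(N3CCN(c4cccc(F)c4)CC3)nn2)n1`: 6 nM
Compound 3 `Cc1nsc(-c2ccc(N3CCN(c4cccc(C#N)c4)CC3)nn2)n1`: 3 nM

These values come from a functional assay (aorta) for inhibition, with Rattus norvegicus as the target; a higher number here means a weaker inhibitor, a lower number a stronger inhibitor. Compound 1 stands at a limit of this assay, with > 100 nM. The two real numbers belong to compound 2 and compound 3, and they cannot be told apart: the gap is a 2.0-fold lower number from compound 2 to compound 3 (0.30 log units; within the scatter).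

The next compound, compound 4 `Cc1nsc(-c2ccc(N3CCN(c4cccc(N)c4)CC3)nn2)n1`, carries amino in place of cyano on an aromatic carbon. For the measured compounds named here, only one measured step bears on this change, namely cyano in place of fluoro on an aromatic carbon, and it amounts to a 2.0-fold lower number from compound 2 to compound 3 (0.30 log units; within the scatter). Going by the values given here, that small step suggests that this aromatic carbon tolerates an exchange, although no measured compound carries amino, so the expectation remains loose. No change beyond the scatter is expected, and no firm direction can be given. The expected change is a 2.0-fold higher number from compound 3 to compound 4 (0.30 log units; within the scatter). Compound 4 is estimated at 6 nM, within an expected range of 1.5 nM to 30 nM.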

Compound 4, half-maximal inhibitory concentration: > 100 nM
Compound 4 gave a limit, no number (the forecaster's own chance of this, stated with the estimate: 5%); at least 16-fold (1.22 log units) between middle value and limit.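

Amino does not fit the tolerant picture that fluoro and cyano gave on this aromatic carbon: an at least 33-fold higher number from compound 3 to compound 4 (1.52 log units; beyond the scatter), and an at least 16-fold higher number from compound 2 to compound 4 (1.22 log units; beyond the scatter). So this carbon of the six-membered aromatic ring does not accept every exchange, and going from 3-cyanophenyl to 3-aminophenyl, a swap that brings in a hydrogen-bond donor, costs far more than the step between fluoro and cyano, which stayed within the scatter. Compound 4 sits at a limit rather than a number, so both steps give only a minimum size: the limit of > 100 nM in this assay, at which 2 of the 4 values shown sit.

Going by these compounds, how far compound 4 really lies beyond that limit stays open. So does whether the loss belongs to amino alone, or would also appear with a hydroxyl, a methoxy or an acetamide on the same carbon.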